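Replacing the Substituted Phenyl of Compound 3 with 4-Fluorophenyl

The compounds below may be only part of what the source reports. "The series", "measured", "known", "first", "only" and "open" are said of these compounds alone.

In a physicochemical assay for lipophilicity (a higher number here means a more lipophilic compound, a lower number a more polar compound), compound 1 `C[C@H]1CC[C@@H]2[C@@H](OC(=O)[C@]23CC(c2ccc(Cl)cc2)=NO3)[C@]2(C)C(=O)C=C[C@@]12O` gives 2.09 and compound 2 `C[C@H]1CC[C@@H]2[C@@H](OC(=O)[C@]23CC(c2ccc(N(C)C)cc2)=NO3)[C@]2(C)C(=O)C=C[C@@]12O` gives 1.51. Compound 3 `COc1cc(C2=NO[C@]3(C2)C(=O)O[C@@H]2[C@H]3CC[C@H](C)[C@]3(O)C=CC(=O)[C@@]23C)ccc1O` stands lowest of the three at 0.75. Compound 4 `C[C@H]1CC[C@@H]2[C@@H](OC(=O)[C@]23CC(c2ccc(F)cc2)=NO3)[C@]2(C)C(=O)C=C[C@@]12O` differs from it in one place: 4-fluorophenyl in place of 4-hydroxy-3-methoxyphenyl on a carbon with a double bond to nitrogen. Two measured steps arrive at the same 4-hydroxy-3-methoxyphenyl group. The large one, starting from 4-chlorophenyl, is a number 1.34 log units lower from compound 1 to compound 3 (beyond the scatter). The modest one, starting from 4-(dimethylamino)phenyl, is a number 0.76 log units lower from compound 2 to compound 3 (beyond the scatter). Among the measured compounds shown here, no fluoro compound has been measured, so the nearest guide is the other compound bearing a halogen, compound 1 at 2.09. The expected change in this assay is a large rise, a number 1.00 log units higher from compound 3 to compound 4 (beyond the scatter). For compound 4 the estimate is 1.75, with an expected range of 1.4 to 2.1.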

Compound 4, partition coefficient: 1.58
For compound 4 the middle estimate is 0.17 log units above the measured one, and the stated range covers the measured number.
By their numbers in this assay, from the lowest: compound 3; then compounds 2 and 4 (each within the scatter of the next); then compound 1.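

Leaving the 4-hydroxy-3-methoxyphenyl group for 4-fluorophenyl gives a number 0.83 log units higher from compound 3 to compound 4 (beyond the scatter) in this assay and so recovers much of the fall seen with that group. The two halogens are not interchangeable at this position, with a number 0.51 log units lower from compound 1 to compound 4 (beyond the scatter) on the change from chloro to fluoro, whereas a number 0.07 log units higher from compound 2 to compound 4 (within the scatter) leaves fluoro and dimethylamino not separable here. Nothing available explains these differences.

Still open, as far as these compounds go, is whether a phenyl carrying only the hydroxy or only the methoxy would account for the low number of compound 3. Where bromo or a carboxylic acid would fall on this ring is also unknown.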